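The source may report more compounds than this note shows. Statements on the series, on what has been measured and on what is new or still open speak of the compounds shown alone.

Compound 1 `O=c1cc(CSC(=S)N2CCCCC2)oc2ccccc12` carries a thiocarbonyl group that bears piperidin-1-yl. In a functional assay on MCF7 cells (Homo sapiens) for antiproliferative activity, read by MTT assay, with a stated time of 72 h (a lower number here means a stronger inhibitor, a higher number a weaker inhibitor), compound 1 gives > 25000 nM, and this is a limit of the assay rather than a number. Compound 1 thus sits at the limit of > 25000 nM in this assay, at which 1 of the 3 values shown sits, the far end of what has been measured.

Two changes to the aromatic part of the core of compound 1 have numbers. Compound 2 `O=c1c(Cl)c(CSC(=S)N2CCCCC2)oc2ccccc12` gives 1000 nM in this assay, and the step of an at least 25-fold lower number from compound 1 to compound 2 (1.39 log units; beyond the scatter). Compound 3 `COc1ccc2oc(CSC(=S)N3CCCCC3)cc(=O)c2c1` gives 10000 nM, and the step of an at least 2.5-fold lower number from compound 1 to compound 3 (0.39 log units; beyond the scatter).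

Compound 4 `O=c1cc(CSC(=S)N2CCOCC2)oc2ccccc12` differs from compound 1 in another region entirely: morpholin-4-yl in place of piperidin-1-yl on a thiocarbonyl carbon. Neither the chloro step nor the methoxy step touches this part of the molecule, so they give no direct guide to it; both concern the aromatic carbons, while compound 4 leaves those untouched. With nothing measured on this side, the expected step is a number no higher from compound 1 to compound 4 (the limit leaves the size open) in this assay, which means no step beyond the scatter, and compound 4 is expected most likely to come back again only as a limit. Compound 4 is estimated at 25000 nM, expected to fall between 8000 nM and 60000 nM.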

Compound 4, half-maximal inhibitory concentration: 21000 nM
Beside the measured number, compound 4's estimate is 1.2-fold (0.08 log units) above it; low and high end bracket the measured number.
By their numbers in this assay, from the lowest: compound 2; then compound 3; then compound 4. At a limit, above all of these: compound 1.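

Compound 4 gives the first reading from the part of the molecule on the thiocarbonyl carbon, rather than from the aromatic part of the core. In this assay, morpholin-4-yl in place of piperidin-1-yl gives an at least 1.1-fold lower number from compound 1 to compound 4 (0.07 log units; that floor lies within the scatter), so the ring oxygen, and the hydrogen-bond acceptor it adds to the count, brings no step that can be shown to lie beyond the scatter. This does not prove that the two groups are equal, since only a floor can be read for this step and its true size stays open, as the value of compound 1 is a limit and not a number: the limit of > 25000 nM in this assay, at which 1 of the 4 values shown sits.

The compounds shown leave open how other groups on the thiocarbonyl carbon would behave, such as an open-chain amine like diethylamino or a ring with a second nitrogen like piperazin-1-yl. They also leave open whether the large step that chloro in place of hydrogen gives from compound 1 to compound 2 would carry over to a compound that bears morpholin-4-yl.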